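This account rests on a few compounds, and the source may have more. Where it says the series, first, only, none or still open, it means among the compounds named here.

Compound 1 `CCOC(=O)c1cnc(NCc2ccc(F)cc2)n2nc(-c3ccco3)nc12` gives 1970 nM in a functional assay on CHO cells for antagonist activity at adenosine receptor A2b (Homo sapiens); on this read-out higher numbers stand for weaker inhibition and lower numbers for stronger inhibition. Compound 2 `CCNc1ncc(C(=O)O)c2nc(-c3ccco3)nn12` reaches only a limit of this assay, > 10000 nM, so its true value is not known. It sits at the limit of > 10000 nM in this assay, at which 1 of the 2 values shown sits.

Compound 3 `COc1ccc(CNc2ncc(C(=O)O)c3nc(-c4ccco4)nn23)cc1` differs from compound 2 in one place: 4-methoxyphenyl in place of methyl on a saturated chain carbon bound to a nitrogen on an aromatic ring. For the measured compounds named here, no two measured compounds here differ in a single place, so the size of this step rests on little. Going by the values given here, compound 1, the only compound with a number, gives 1970 nM. The step from compound 2 to compound 3 is expected to be an at least 2.0-fold lower number from compound 2 to compound 3 (0.30 log units; that floor lies within the scatter), toward stronger inhibition. Compound 3 is estimated at 5000 nM, with a range from 1500 nM to 20000 nM.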

Compound 3, inhibition constant: > 30000 nM
Compound 3: a limit, no number (the forecaster's own chance of this, stated with the estimate: 30%); middle value at least 6.0-fold (0.77 log units) from the limit.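

Compound 2 and compound 3 each reach only a limit in this assay, so the step between them cannot be read. As far as these compounds go, it remains open whether 4-methoxyphenyl in place of methyl changes inhibition at all.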